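Swapping chloro for methyl on the core of compound 2

The compounds below may be only part of what the source reports. "The series", "measured", "known", "first", "only" and "open" are said of these compounds alone.

Measured compounds:
- compound 1, `Cc1cc(-c2cc(C)c(OC[C@@](C)(N)CC(C)C)cn2)ccn1`: 19 nM
- compound 2, `COC(=O)Nc1cc(-c2cc(Cl)c(OC[C@@](C)(N)CC(C)C)cn2)ccn1`: 1.1 nM
- compound 3, `CC(C)C[C@](C)(N)COc1cnc(-c2ccnc(Cl)c2)cc1Cl`: 2.3 nM

In an assay on isolated protein for inhibition of AP2-associated protein kinase 1 (Homo sapiens), with a stated time of 3 h, in the presence of a further agent that is not named here (a lower number here means a stronger inhibitor, a higher number a weaker inhibitor), compound 2 gives 1.1 nM and stands lowest of the three numbers; compound 3 is nearest, with a 2.1-fold higher number from compound 2 to compound 3 (0.32 log units; beyond the scatter), and compound 1 is furthest, giving 19 nM.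

Compound 4, `COC(=O)Nc1cc(-c2cc(C)c(OC[C@@](C)(N)CC(C)C)cn2)ccn1`, has not been measured. It differs from compound 2 in one place: methyl in place of chloro on an aromatic carbon. Within the data shown here, the one measured step, a 2.1-fold higher number from compound 2 to compound 3 (0.32 log units; beyond the scatter), concerns a different position and a different pair of groups, so no measured step bears directly on this change. Compound 1 and compound 3 differ in two places at once and cannot separate the effect of this exchange; their values only show that the compound bearing methyl groups gives the higher number.

Among the measured compounds shown here, with no direct precedent, compound 4 is expected to sit close to compound 2, with at most a modest rise, an estimated 2.5 nM within 0.9 nM to 7 nM, meaning an expected step of a 2.3-fold higher number from compound 2 to compound 4 (0.36 log units; beyond the scatter).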

Compound 4, half-maximal inhibitory concentration: 1.7 nM
For compound 4 the middle estimate is 1.5-fold (0.17 log units) above the measured one, and the stated range covers the measured number.
By their numbers in this assay, from the lowest: compounds 2, 4 and 3 (each within the scatter of the next, the first and the last beyond it); then compound 1.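

In this assay methyl in place of chloro, on the carbon ortho to the (2-amino-2,4-dimethylpentyl)oxy group, gives a 1.5-fold higher number from compound 2 to compound 4 (0.19 log units; within the scatter) and so no difference that can be told from the scatter, at least with the (methoxycarbonyl)amino group present. With methyl held at this position, (methoxycarbonyl)amino in place of methyl on the other aromatic carbon gives an 11-fold lower number from compound 1 to compound 4 (1.05 log units; beyond the scatter) in a single-place comparison, so the large step among these compounds lies at that other carbon and not at this position. No measurement is available that explains either result. As far as these compounds go, what a methoxy group, a nitrile or a plain hydrogen would do at this position stays open. So does whether chloro and methyl also read alike when chloro replaces the (methoxycarbonyl)amino group, as it does in compound 3.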